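The source may hold more compounds than are shown below. What is called first, only, known or untested is meant among the compounds shown, and "the series" means these compounds.

Compound 2 `O=C1C(Nc2cccc(Cl)c2)=CC(=O)c2c1nc1n2[C@H]2OC[C@@H](O)[C@H]2OC1` carries a 3-chlorophenyl on the amine nitrogen of the shared core, and in a functional assay on HeLa cells (Homo sapiens) for inhibition, read by sulforhodamine B assay (a lower number here means a stronger inhibitor, a higher number a weaker inhibitor), compound 2 gives 7970 nM. Compound 1 `Cc1ccc(NC2=CC(=O)c3nc4n(c3C2=O)[C@H]2OC[C@@H](O)[C@H]2OC4)cc1` gives 3860 nM, so compound 2 holds the higher of the two numbers shown. Compound 3 `O=C1C=C(NCc2ccccc2)C(=O)c2c1nc1n2[C@H]2OC[C@@H](O)[C@H]2OC1` reaches only a limit of this assay, > 8000 nM. The change to compound 4 `O=C1C(NC2CCCC2)=CC(=O)c2c1nc1n2[C@H]2OC[C@@H](O)[C@H]2OC1` is cyclopentyl in place of 3-chlorophenyl on an amine nitrogen. Among the measured compounds shown here, the one measured step that resembles it, an at least 2.0-fold higher number from compound 1 to compound 3 (0.31 log units; beyond the scatter), also replaced an aryl group on that nitrogen and weakened inhibition, though its full size stays unknown because of the limit of > 8000 nM in this assay, at which 1 of the 3 values shown sits. The same direction is therefore expected, as an estimated step of a 1.8-fold higher number from compound 2 to compound 4 (0.24 log units; within the scatter). Compound 4 is expected near 14000 nM, between 5000 nM and 40000 nM.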

Compound 4, half-maximal inhibitory concentration: > 16000 nM
Compound 4: no number, only a limit (the forecaster's own chance of this, stated with the estimate: 65%); middle value at least 1.1-fold (0.05 log units) from the limit.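

Putting cyclopentyl on the amine nitrogen in place of 3-chlorophenyl gives an at least 2.0-fold higher number from compound 2 to compound 4 (0.30 log units; that floor lies within the scatter), so the floor of this change alone does not clear the usual scatter. Compound 4 gives no number, only a limit: the limit of > 16000 nM in this assay, at which 1 of the 4 values shown sits. Before this, benzyl in compound 3 was the only non-aryl group shown on this nitrogen; now a non-aromatic ring attached directly to it also ends at a limit, while the aryl groups of compound 1 and compound 2 give numbers.

From the compounds shown here alone, the true size of this step stays unknown. Going by these compounds, whether an open chain such as butyl, or a pyridyl ring, on this nitrogen would give a number also remains open.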